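Oxazole in place of propylcarbonyl: notes toward compound 4

This account rests on a few compounds, and the source may have more. Where it says the series, first, only, none or still open, it means among the compounds named here.

Three compounds share one core and differ only in the group on the double-bonded ring carbon. In an assay on membranes from HeLa cells for displacement of a labelled ligand from adenosine receptor A3 (Homo sapiens), read by scintillation counting, with a stated time of 180 min, tested at 1 uM (on this read-out higher numbers stand for more inhibition at the one concentration tested (going by the name of the read-out) and lower numbers for less inhibition), compound 1 `CC1=C(C(=O)OCC(C)C)C(c2cccs2)NC(=O)N1` gives 11%, compound 2 `CCCC(=O)C1=C(C)NC(=O)NC1c1cccs1` gives 2% and compound 3 `CCN(CC)C(=O)C1=C(C)NC(=O)NC1c1cccs1` gives 31%. Compound 2 stands lowest of the three: its gap to compound 1 is within the scatter, its gap to compound 3 beyond it. The measured steps are a number 9 percentage points lower from compound 1 to compound 2 (within the scatter), a number 20 percentage points higher from compound 1 to compound 3 (beyond the scatter) and a number 29 percentage points higher from compound 2 to compound 3 (beyond the scatter); each exchanges the group on the carbonyl carbon, and the largest of them is modest.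

Compound 4 `CC1=C(c2ncc(C)o2)C(c2cccs2)NC(=O)N1` differs from compound 2 by 5-methyl-1,3-oxazol-2-yl in place of propylcarbonyl on a double-bonded ring carbon. Within the data shown here, no measured step removes the carbonyl itself, so the three steps bear on it only as a gauge of how far this position moves the read-out in this assay. On that gauge a shift of at most modest size is expected, more likely upward than downward because compound 2 holds the lowest number 2%. The estimate for compound 4 in this assay is 10%, with a range from -5% to 35%. The step this expectation implies is a number 8 percentage points higher from compound 2 to compound 4 (within the scatter).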

Compound 4, a percentage reported as inhibition, at one concentration (the size of the read-out at that concentration, not a potency): 1%
For compound 4 the middle estimate is 9 percentage points above the measured one, within the range that was stated.
By their numbers in this assay, from the lowest: compounds 4, 2 and 1 (each within the scatter of the next); then compound 3.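

In this assay, the step is a number 1 percentage points lower from compound 2 to compound 4 (within the scatter), so this exchange leaves the reading of compound 2 unchanged within the scatter. All earlier steps kept a carbonyl on the double-bonded ring carbon, whereas compound 4 carries a one five-membered aromatic ring there without one, and its number still cannot be told apart from that of compound 2; with both numbers this low, the result shows no benefit from the exchange, and any loss would be hard to read. Nothing available explains this outcome.

Among these compounds, still open is whether a carboxylic acid or a piperidine amide on this ring carbon would read differently from compound 3, the only compound here set apart from compound 2 beyond the scatter. Also open, on these data alone, is whether a longer chain in place of the methyl on the oxazole would move the number at all.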